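This account rests on a few compounds, and the source may have more. Where it says the series, first, only, none or still open, it means among the compounds named here.

Series notes. Compound 1 `COc1ccc(/C=C/C(=O)c2sc(Nc3ccc(Cl)cc3)nc2C)cc1`, compound 2 `COc1cccc(/C=C/C(=O)c2sc(Nc3cccc(C)c3)nc2C)c1` and compound 3 `COc1cc(/C=C/C(=O)c2sc(Nc3ccc(Cl)cc3)nc2C)cc(OC)c1OC` share a core and differ only in the groups carried on their aromatic rings. In a functional assay on PC-3 cells (Homo sapiens) for cytotoxicity, read by MTT assay (on this read-out higher numbers stand for weaker inhibition and lower numbers for stronger inhibition), compound 1 gives > 25000 nM, which is a limit of the assay rather than a number. In this assay compound 2 likewise gives > 25000 nM, again a limit. In this assay compound 3 gives > 25000 nM, also a limit. Compound 2 therefore stands exactly where every value shown stands, at the limit of > 25000 nM in this assay, at which 3 of the 3 values shown sit; no ordering among the three compounds is possible from these numbers. Compound 4 `COc1cccc(/C=C/C(=O)c2sc(Nc3ccccc3)nc2C)c1` is not yet measured. It differs from compound 2 by hydrogen in place of methyl on an aromatic carbon. Within the data shown here, no step between two measured compounds is available, so the size of any single change is not known here. With compound 2 sitting at a limit in this assay, the step from compound 2 to compound 4 is estimated as a step that the limit leaves unreadable from compound 2 to compound 4, none beyond the scatter, and a further limit is the most likely outcome. Compound 4 is expected at 30000 nM, range 8000 nM to 100000 nM.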

Compound 4, half-maximal inhibitory concentration: > 25000 nM
Compound 4: a limit, no number; the forecaster's own chance of this, stated with the estimate: 80%; the middle value lies beyond the limit too.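

No step can be read from compound 2 to compound 4, as both stand at a limit and neither gives a number: the limit of > 25000 nM in this assay, at which 4 of the 4 values shown sit.

The compounds shown leave open which change to the groups on the shared core, if any, would give a number in this assay rather than a limit.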